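Extending the amine substituent from hexyl to decyl

The compounds below may be only part of what the source reports. "The series", "measured", "known", "first", "only" and "open" are said of these compounds alone.

Measured compounds:
- compound 1, `CCCCCCCCCCCCCCC(N)CO`: 15.1%
- compound 2, `CCCCCCCCCCCCCCC(CO)NCCCC`: "not determined" (no result reported)
- compound 3, `CCCCCCCCCCCCCCC(CO)NCCCCCC`: 5%

All three compounds share a long-chain amino alcohol core and differ only in what sits on the amine nitrogen. In an ADME assay on cells (Splenocyte, Mus musculus, strain BALB/c) for cytotoxicity, read by MTT assay, tested at 1 ug/mL (a lower number here means a weaker effect, a higher number a stronger effect of the compound at the concentration tested), compound 1 gives 15.1%, while compound 3 gives 5%. For compound 2 the result reads "not determined" (no result reported). Among the measured compounds shown here, compound 3 therefore holds the lowest of the two numbers available, and its one step, a number 10.1 percentage points lower from compound 1 to compound 3 (beyond the scatter), is the only measured change that can guide an expectation.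

Compound 4, `CCCCCCCCCCCCCCC(CO)NCCCCCCCCCC`, carries the change (butyl in place of hydrogen on a saturated chain carbon, six bonds along the chain from an amine nitrogen). For the measured compounds named here, this is the same kind of change as the one measured step, carried further along the chain. That step was a modest lowering, and compound 3 already sits close to the bottom of the scale, leaving little room for a further drop. For compound 4 the step of a number 2 percentage points higher from compound 3 to compound 4 (within the scatter) is expected to stay within the scatter, and compound 4 is estimated at 7%, between 0% and 20%.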

Compound 4, a percentage reported as activity, at one concentration (the size of the read-out at that concentration, not a potency): 6.6%
The estimate for compound 4 lay 0.4 percentage points above the measured number, within the range that was stated.
By their numbers in this assay, from the lowest: compounds 3, 4 and 1 (each within the scatter of the next, the first and the last beyond it).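

In this assay, adding butyl on a saturated chain carbon, six bonds along the chain from an amine nitrogen, gives a number 1.6 percentage points higher from compound 3 to compound 4 (within the scatter). Extending the hexyl group to decyl therefore produces no readable change, whereas the earlier replacement of hydrogen by hexyl gave a number 10.1 percentage points lower from compound 1 to compound 3 (beyond the scatter). Nothing shown here offers an explanation for this result.

Going by these compounds, it remains open whether a different group in place of the decyl chain, such as a phenyl ring or a carboxylic acid, would give a number beyond the scatter of compound 3 in this assay. Compound 2, with its butyl group, has no reported result, so the shorter end of this series also stays unresolved.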